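The compounds below may be only part of what the source reports. "The series", "measured", "known", "first", "only" and "open" are said of these compounds alone.

In an ADME assay on Huh-7 cells (Homo sapiens) for cytotoxicity, read by colorimetric assay (a lower number here means that less compound is tolerated, a higher number that more compound is tolerated), compound 2, whose structure is `COc1ccc2c(O[C@H]3C[C@H]4C(=O)N(C)CCCC/C=C/[C@@H]5C[C@@]5(C(=O)NS(=O)(=O)C5(C)CC5)NC(=O)N4C3)cc(-c3nc(C4CCC4)cs3)nc2c1Cl`, gives 75000 nM. Among the compounds with values here, the only other compound measured in this assay is compound 1, with the structure `COc1ccc2c(O[C@H]3C[C@H]4C(=O)N(C)CCCC/C=C/[C@@H]5C[C@@]5(C(=O)NS(=O)(=O)C5(C)CC5)NC(=O)N4C3)cc(-c3nc(C(C)C)cs3)nc2c1Br`, and in this assay compound 1 gives 51200 nM. The gap between these two numbers lies within the usual scatter of repeated measurements, so the two compounds cannot be told apart on this read-out.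

Compound 3, with the structure `COc1ccc2c(O[C@H]3C[C@H]4C(=O)N(C)CCCC/C=C/[C@@H]5C[C@@]5(C(=O)NS(=O)(=O)C5(C)CC5)NC(=O)N4C3)cc(-n3cc(C(C)C)nn3)nc2c1Cl`, has not yet been measured in this assay. It differs from compound 2 in one place: 4-isopropyl-1H-1,2,3-triazol-1-yl in place of 4-cyclobutyl-1,3-thiazol-2-yl on an aromatic carbon. No step between two measured compounds of this kind has been shown, so there is nothing in the numbers to point in either direction. The expected change in this assay from compound 2 to compound 3 is a 1.3-fold lower number from compound 2 to compound 3 (0.10 log units; within the scatter), which is not beyond the scatter. On that basis compound 3 is estimated to give 60000 nM in this assay, with a range from 25000 nM to 150000 nM.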

Compound 3, half-maximal cytotoxic concentration: 28500 nM
Compound 3: the middle estimate sits 2.1-fold (0.32 log units) above what was measured, and the stated range covers the measured number.
By their numbers in this assay, from the lowest: compounds 3, 1 and 2 (each within the scatter of the next, the first and the last beyond it).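

In this assay the group on the aromatic carbon next to the ring nitrogen can shift the result: putting 4-isopropyl-1H-1,2,3-triazol-1-yl in place of 4-cyclobutyl-1,3-thiazol-2-yl brings a 2.6-fold lower number from compound 2 to compound 3 (0.42 log units; beyond the scatter), so less compound is tolerated. Within the data shown here, this is a modest step, but it is the first single change to stand clear of the scatter, as the earlier two compounds differ in more than one place. Nothing available accounts for the shift.

As far as these compounds go, this one step swaps the aromatic ring and its side group together, so the share of each remains unknown. Also open, from the compounds shown here alone, is how a smaller or differently built group at this position, such as an amine or a phenyl ring, would behave.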